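Working notes: from 5-chloropyridin-2-yl to 2,4-dichlorophenyl

The compounds below may be only part of what the source reports. "The series", "measured", "known", "first", "only" and "open" are said of these compounds alone.

In a physicochemical assay for solubility, in simulated intestinal fluid, with a stated time of 4 h (on this read-out lower numbers stand for lower solubility and higher numbers for higher solubility), compound 1 `N#Cc1ccc(O[C@H]2CN(S(=O)(=O)c3ccc(Cl)cc3Cl)C[C@@]2(O)CN)cc1F` gives 78 ug/mL and compound 2 `N#Cc1ccc(O[C@H]2CN(S(=O)(=O)c3ccc(C(F)(F)F)cc3C#N)C[C@@]2(O)CO)cc1F` gives 25 ug/mL on the same read-out. Compound 3 `N#Cc1ccc(S(=O)(=O)[C@H]2CN(S(=O)(=O)c3ccc(Cl)cn3)C[C@@]2(O)CO)cc1` reads > 1000 ug/mL as a limit of the assay, not a number. Compound 4 `N#Cc1ccc(S(=O)(=O)[C@H]2CN(S(=O)(=O)c3ccc(Cl)cc3Cl)C[C@@]2(O)CO)cc1` differs from compound 3 by 2,4-dichlorophenyl in place of 5-chloropyridin-2-yl on a sulfonyl sulfur. For the measured compounds named here, no measured pair isolates this change. Compound 1 carries the same 2,4-dichlorophenyl on a sulfonyl sulfur and gives 78 ug/mL on a different core, so a large downward step beyond the scatter is expected in this assay here. The estimated step of an at least 16-fold lower number from compound 3 to compound 4 (1.22 log units; beyond the scatter) is downward. Compound 4 is estimated at 60 ug/mL with a range from 15 ug/mL to 250 ug/mL on this read-out.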

Compound 4, solubility: 270 ug/mL
Beside the measured number, compound 4's estimate is 4.5-fold (0.65 log units) below it; the measured number lies above the stated range.
By their numbers in this assay, from the lowest: compound 2; then compound 1; then compound 4. At a limit, above all of these: compound 3.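

In this assay, 2,4-dichlorophenyl in place of 5-chloropyridin-2-yl on a sulfonyl sulfur gives an at least 3.7-fold lower number from compound 3 to compound 4 (0.56 log units; beyond the scatter). Compound 4 stays at 270 ug/mL with this group, a measured number on the shared core. The step gives only a lower bound on its size, and the full drop cannot be read, as compound 3 stands at a limit of the assay: the limit of > 1000 ug/mL in this assay, at which 1 of the 4 values shown sits.

The compounds shown do not separate the ring nitrogen from the added chlorine. On these data alone, how a sulfonyl substituent carrying an amine or a carboxylic acid would read in this assay stays open.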